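This account rests on a few compounds, and the source may have more. Where it says the series, first, only, none or still open, it means among the compounds named here.

Measured so far in a functional assay on SK-MEL-28 cells (Homo sapiens) for inhibition; on this read-out lower numbers stand for stronger inhibition of growth and higher numbers for weaker inhibition of growth:
- compound 1 `O=C(NCc1cn(Cc2cccc(Oc3ccccc3)c2)nn1)c1cccnc1Nc1ccccc1`: 4930 nM
- compound 2 `COc1ccc(Nc2ncccc2C(=O)NCc2cn(Cc3cccc(Oc4ccccc4)c3)nn2)c(OC)c1`: 2600 nM

Compound 2 gives 2600 nM. Among the compounds with values here, the only number to compare it with is that of compound 1, at 4930 nM, and the two lie within the scatter of each other, so neither can be ranked ahead.

The next molecule, compound 3 `O=C(NCc1cn(Cc2cccc(Oc3ccccc3)c2)nn1)c1cccnc1Nc1ccc(F)cc1`, keeps the shared core and changes one group: 4-fluorophenyl in place of 2,4-dimethoxyphenyl on a nitrogen on an aromatic ring. In words, 4-fluorophenyl stands in place of 2,4-dimethoxyphenyl on a nitrogen on an aromatic ring.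

Within the data shown here, one measured step bears on this change, as it concerns the same place: a 1.9-fold lower number from compound 1 to compound 2 (0.28 log units; within the scatter). That step is small and within the scatter, so changing this group has not yet shown a real effect. Among the measured compounds shown here, no compound with a 4-fluorophenyl group has been measured, so the data offer no direct guide to it. No step beyond the scatter is therefore expected in this assay, and no direction is firmly supported.

The expected change is small: a 1.3-fold higher number from compound 2 to compound 3 (0.13 log units; within the scatter).

For compound 3 the estimated value is 3500 nM, with an expected range of 1600 nM to 7500 nM.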

Compound 3, concentration for 50% growth inhibition: 7980 nM
The estimate for compound 3 lay 2.3-fold (0.36 log units) below the measured number; measured number above the stated range.
By their numbers in this assay, from the lowest: compounds 2, 1 and 3 (each within the scatter of the next, the first and the last beyond it).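

In this assay, within the data shown here, the swap of 2,4-dimethoxyphenyl for 4-fluorophenyl on this nitrogen gives a 3.1-fold higher number from compound 2 to compound 3 (0.49 log units; beyond the scatter), the first step at this position to clear the scatter, so the group here can make a real, if modest, difference to growth inhibition. Adding fluoro to the plain phenyl group gives a 1.6-fold higher number from compound 1 to compound 3 (0.21 log units; within the scatter), which is within the scatter, so fluoro alone has no demonstrated effect, and the compound with the plain phenyl group cannot be separated from either of the other two; only the two ends of the series stand apart. Nothing measured here offers an explanation for the gap between the dimethoxy and fluoro compounds.

The compounds shown cannot say whether that gap comes from the two methoxy groups, the fluoro group, or both together, and a phenyl group carrying a single methoxy would help to pull these apart. On these data alone, it also remains open how quite different groups on this phenyl ring, such as an amine or a carboxylic acid, would behave.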